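The source may report more compounds than this note shows. Statements on the series, on what has been measured and on what is new or still open speak of the compounds shown alone.

Measured compounds:
- compound 1 `COc1ccc(-c2cnc(NC(=O)c3cnco3)n2C)cc1`: > 100000 nM
- compound 2 `Cn1c(-c2ccccc2[N+](=O)[O-])cnc1NC(=O)c1ccc(F)cc1`: 31000 nM

In a toxicity assay on THP-1 cells (Homo sapiens) for inhibition (on this read-out lower numbers stand for higher toxicity in this test and higher numbers for lower toxicity in this test), compound 1 gives only a limit, > 100000 nM, and no number. Compound 1 thus sits at the limit of > 100000 nM in this assay, at which 1 of the 2 values shown sits. Compound 2 gives 31000 nM in this assay. Compound 3 `COc1ccc(-c2cnc(NC(=O)c3ccc(F)cc3)n2C)cc1` differs from compound 1 by 4-fluorophenyl in place of 1,3-oxazol-5-yl on a carbonyl carbon. Going by the values given here, no measured step is available for this change. The step of an at least 1.6-fold lower number from compound 1 to compound 3 (0.22 log units; that floor lies within the scatter) is expected to be small, toward higher toxicity, and possibly within the scatter. Compound 3 is expected in this assay at 60000 nM, in a range from 20000 nM to 150000 nM.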

Compound 3, half-maximal cytotoxic concentration: >= 50000 nM
Compound 3 gave a limit, no number; the forecaster's own chance of this, stated with the estimate: 40%; the middle value is on the limit's open side.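

Going by these compounds alone, compound 1 and compound 3 each give only a limit, so no step between them can be read. The compounds shown leave open whether 4-fluorophenyl in place of 1,3-oxazol-5-yl on a carbonyl carbon shifts the half-maximal cytotoxic concentration at all.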